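Cytotoxicity notes: from compound 3 to compound 4

This account rests on a few compounds, and the source may have more. Where it says the series, first, only, none or still open, it means among the compounds named here.

Compound 1 `CCOC(=O)CCCCCOc1cccc(CN(C(=O)c2ccc(-c3cccc4ccccc34)cc2)C(C)C)c1`, compound 2 `CCOC(=O)CCCCCOc1cccc(CN(C(=O)c2ccc(-c3cccc(OCC(C)C)c3)cc2)C(C)C)c1` and compound 3 `CCOC(=O)CCCCCOc1cccc(CN(C(=O)c2ccc(-c3cccc(-c4nnc(C)o4)c3)cc2)C(C)C)c1` share one core and differ only in the group on an aromatic carbon. In an ADME assay on BJ cells (Homo sapiens) for cytotoxicity, read by CellTiter-Glo and resazurin assay, with a stated time of 72 h (a lower number here means that less compound is needed, a higher number that more compound is needed for the effect), compound 1 gives > 26000 nM, which is a limit of the assay. In this assay compound 2 gives > 26000 nM, again a limit. Compound 3 stands at a limit as well, > 26000 nM in this assay. The steps a step that the two limits leave unreadable from compound 1 to compound 2, a step that the two limits leave unreadable from compound 1 to compound 3 and a step that the two limits leave unreadable from compound 2 to compound 3 are unreadable because of the limit of > 26000 nM in this assay, at which 3 of the 3 values shown sit. Compound 4 `CCOC(=O)CCCCCOc1cccc(CN(C(=O)c2ccc(-c3cccc(C(F)(F)F)c3)cc2)C(C)C)c1` differs from compound 3 by trifluoromethyl in place of 5-methyl-1,3,4-oxadiazol-2-yl on an aromatic carbon. Going by the values given here, no measured step constrains this change. Compound 4 is expected to sit near the same limit, the step that the limit leaves unreadable from compound 3 to compound 4 being an estimate only. Compound 4 is estimated at 30000 nM, range 12000 nM to 80000 nM.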

Compound 4, half-maximal effective concentration: < 1.3 nM
Compound 4 was reported as a limit; the forecaster's own chance of this, stated with the estimate: 75%; middle value at least 23000-fold (4.36 log units) away from the limit.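

In this assay, trifluoromethyl on this aromatic carbon gives an at least 20000-fold lower number from compound 3 to compound 4 (4.30 log units; beyond the scatter), in place of 5-methyl-1,3,4-oxadiazol-2-yl, and an at least 20000-fold lower number from compound 2 to compound 4 (4.30 log units; beyond the scatter), in place of isobutoxy; 3-(trifluoromethyl)phenyl in place of naphthalen-1-yl gives an at least 20000-fold lower number from compound 1 to compound 4 (4.30 log units; beyond the scatter). The earlier compounds showed no response to changes at this position, whereas this change, on an unchanged shared core, moves the read-out across the whole range shown. These steps are bounds, not exact sizes: the limit of < 1.3 nM in this assay, at which 1 of the 4 values shown sits.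

On these data alone, whether the drop is specific to trifluoromethyl stays open. A chlorine or a nitrile on the same aromatic carbon would help to show this.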